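Working notes on cytotoxicity across a four-compound series

This account rests on a few compounds, and the source may have more. Where it says the series, first, only, none or still open, it means among the compounds named here.

Compound 1 `COc1ccc(N/N=C2\C(=O)N(Cc3cn(O[C@@H]4O[C@H](CC(C)=O)[C@@H](OC(C)=O)[C@H](OC(C)=O)[C@H]4OC(C)=O)nn3)c3ccccc32)cc1` gives 95300 nM in an ADME assay on Vero cells (Chlorocebus sabaeus) for cytotoxicity, read by fluorescence and resazurin assay, with a stated time of 3 days; on this read-out higher numbers stand for lower toxicity in this test and lower numbers for higher toxicity in this test. Compound 2 `CC(=O)C[C@H]1O[C@@H](On2cc(CN3C(=O)/C(=N\Nc4ccc(C#N)cc4)c4ccccc43)nn2)[C@H](OC(C)=O)[C@@H](OC(C)=O)[C@@H]1OC(C)=O` gives 75400 nM in this assay; the change from compound 1 is cyano in place of methoxy on an aromatic carbon, and the step is a 1.3-fold lower number from compound 1 to compound 2 (0.10 log units; within the scatter). Compound 3 `COc1ccc(N/N=C2\C(=O)N(Cc3cn(O[C@@H]4O[C@H](CC(C)=O)[C@H](OC(C)=O)[C@H](OC(C)=O)[C@H]4OC(C)=O)nn3)c3ccccc32)cc1` gives 62500 nM in this assay. Compounds 1 and 3 differ by the two compounds have the same atoms and bonds and differ only in configuration as drawn: 1 of 6 stereo elements differ; a stereocentre at a saturated ring carbon is drawn R in compound 1 and S in compound 3, and the step of a 1.5-fold lower number from compound 1 to compound 3 (0.18 log units; within the scatter) rests on nothing more than the fact that compounds 1 and 3 differ only in the configuration as drawn. Compound 4 `CC(=O)C[C@H]1O[C@@H](On2cc(CN3C(=O)/C(=N\Nc4ccc(C#N)cc4)c4ccccc43)nn2)[C@H](OC(C)=O)[C@@H](OC(C)=O)[C@H]1OC(C)=O` is not yet measured. It differs from compound 3 by cyano in place of methoxy on an aromatic carbon, the same change as from compound 1 to compound 2, at the same place. For compound 4 in this assay the step from compound 3 is expected to be a 1.3-fold lower number from compound 3 to compound 4 (0.10 log units; within the scatter), resting on the earlier step of a 1.3-fold lower number from compound 1 to compound 2 (0.10 log units; within the scatter). Compound 4 is estimated at 50000 nM, between 25000 nM and 100000 nM.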

Compound 4, half-maximal cytotoxic concentration: 75500 nM
For compound 4 the middle estimate is 1.5-fold (0.18 log units) below the measured one; measured number inside the range.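

In this assay cyano in place of methoxy gives a 1.2-fold higher number from compound 3 to compound 4 (0.08 log units; within the scatter) and, set beside the earlier step, the change reads the same on both cores within the scatter: the same change on two cores in this assay, a 1.3-fold lower number (0.10 log units; within the scatter) from compound 1 to compound 2 and a 1.2-fold higher number (0.08 log units; within the scatter) from compound 3 to compound 4, 1.5-fold (0.18 log units) apart, within the scatter of two such steps

The configuration step on the cyano compounds is a 1.0-fold higher number from compound 2 to compound 4 (0.00 log units; within the scatter) and it rests on no more than this: the fact that compounds 2 and 4 differ only in the configuration as drawn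

Cyano for methoxy thus carries from the core of compound 1 to the core of compound 3 without a step beyond the scatter, but with no step of measurable size on either core, this shows no effect that transfers, only the absence of a visible one.

From the compounds shown here alone, whether a nitro group, an amine or a carboxylic acid at the same place would give a step beyond the scatter stays open. Also open, going by these compounds, is whether such a step would hold on both cores.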